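The source may hold more compounds than are shown below. What is called first, only, known or untested is meant among the compounds shown, and "the series" means these compounds.

Measured in a functional assay on SK-BR-3 cells (Homo sapiens) for antiproliferative activity, read by MTT assay, with a stated time of 72 h; a higher number here means a weaker inhibitor, a lower number a stronger inhibitor:
Compound 1 `CN(C)C/C=C/C(=O)Nc1cc2ncnc(Nc3ccc(F)c(Cl)c3)c2cc1O[C@@H]1CCOC1` gives 5560 nM.
Compound 2 `C=CC(=O)Nc1cc2c(Nc3ccc(F)c(Cl)c3)ncnc2cc1OCc1cn(CCCCC(=O)NO)nn1` gives 20000 nM.
Compound 3 `C=CC(=O)Nc1cc2c(Nc3cccc(Cl)c3F)ncnc2cc1OCc1cn(CCCCC(=O)NO)nn1` reaches only a limit of the assay, > 50000 nM.

Compound 3 therefore stands apart from the other two in that its result is a limit rather than a number, while compound 1 and compound 2 each give a measured value. Among the measured compounds shown here, the only step among the measured compounds, an at least 2.5-fold higher number from compound 2 to compound 3 (0.39 log units; beyond the scatter), is itself open-ended because it rests on (the limit of > 50000 nM in this assay, at which 1 of the 3 values shown sits). Compound 4 `C=CC(=O)Nc1cc2c(Nc3cccc(Cl)c3F)ncnc2cc1OCc1cn(CCC(=O)NO)nn1` differs from compound 3 elsewhere: hydroxycarbamoyl in place of 2-(hydroxycarbamoyl)ethyl on a saturated chain carbon, two bonds along the chain from an aromatic nitrogen. For the measured compounds named here, none of the measured pairs varies this part of the molecule, so the single measured step does not bear on the change in hand, and the hydroxycarbamoyl end is left without any precedent in these data. Starting from a limit, the step that the limit leaves unreadable from compound 3 to compound 4 is expected to be none beyond the scatter, with the result for compound 4 most probably again reported only as a limit. Compound 4 is accordingly estimated at about 60000 nM in this assay, within a range from 25000 nM to 150000 nM.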

Compound 4, half-maximal inhibitory concentration: > 50000 nM
Compound 4 gave a limit, no number; the forecaster's own chance of this, stated with the estimate: 70%; the middle value does not contradict the limit.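

In this assay compound 4 gives > 50000 nM, which is a limit of the assay and not a number. Compound 3 also rests on a limit, so no step can be read between compound 3 and compound 4: the limit of > 50000 nM in this assay, at which 2 of the 4 values shown sit.

The compounds shown leave open whether hydroxycarbamoyl in place of 2-(hydroxycarbamoyl)ethyl changes the result in this assay at all.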